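Replacing hydroxy with dimethylamino at the chain carbon

The compounds below may be only part of what the source reports. "The series", "measured", "known", "first", "only" and "open" are said of these compounds alone.

Measured in a functional assay on U2OS cells for antagonist activity at C-X-C chemokine receptor type 3 (Homo sapiens), read by beta-arrestin recruitment; a higher number here means a weaker inhibitor, a lower number a stronger inhibitor:
compound 1 `Cc1nc(-c2nc3ccccc3[nH]2)c(N2CCN(C(=O)Cn3cnc4cccnc43)[C@H](C)C2)s1` gives 1050 nM.
compound 2 `C[C@@H]1CN(c2sc(Br)nc2-c2nc3ccccc3[nH]2)CCN1C(=O)Cn1cnc2cccnc21` gives 126 nM.
compound 3 `C[C@@H]1CN(c2sc(CO)nc2-c2nc3ccccc3[nH]2)CCN1C(=O)Cn1cnc2cccnc21` gives only a limit, > 10000 nM.

From the compounds shown here alone, compound 3 is the weakest of the three: it sits at the limit of > 10000 nM in this assay, at which 1 of the 3 values shown sits, so its true value is unknown beyond that bound. Both steps leading to it are clear. Going an at least 9.5-fold higher number from compound 1 to compound 3 (0.97 log units; beyond the scatter), a hydroxy placed on the saturated chain carbon costs potency; going an at least 79-fold higher number from compound 2 to compound 3 (1.89 log units; beyond the scatter) the loss is larger still. The step of an 8.3-fold lower number from compound 1 to compound 2 (0.92 log units; beyond the scatter) shows that the substituent on this aromatic carbon matters in the other direction too.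

Compound 4 `C[C@@H]1CN(c2sc(CN(C)C)nc2-c2nc3ccccc3[nH]2)CCN1C(=O)Cn1cnc2cccnc21` carries the change (dimethylamino in place of hydroxy on a saturated chain carbon bound to an aromatic carbon). For the measured compounds named here, no measured pair touches a dimethylamino group, so the expectation rests only on the observation that the hydroxymethyl of compound 3 is the worst substituent seen and that any change away from it has room to recover. The expected step of an at least 2.0-fold lower number from compound 3 to compound 4 (0.30 log units; that floor lies within the scatter) is therefore a modest improvement, in the direction of lower numbers, with wide uncertainty. For compound 4 the estimate in this assay is 5000 nM, from 1500 nM to 20000 nM.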

Compound 4, half-maximal inhibitory concentration: 2360 nM
Beside the measured number, compound 4's estimate is 2.1-fold (0.33 log units) above it, within the range that was stated.
By their numbers in this assay, from the lowest: compound 2; then compound 1; then compound 4. At a limit, above all of these: compound 3.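

In this assay, from the compounds shown here alone, the chain carbon bound to an aromatic carbon responds to the group it carries and not only to being substituted: dimethylamino in place of hydroxy gives a clear recovery (an at least 4.2-fold lower number from compound 3 to compound 4 (0.62 log units; beyond the scatter)), whose true size stays open, as compound 3 is only a limit: the limit of > 10000 nM in this assay, at which 1 of the 4 values shown sits.

The recovery is partial, as the chain carbon carrying dimethylamino still falls short of the unsubstituted methyl (a 2.2-fold higher number from compound 1 to compound 4 (0.35 log units; beyond the scatter)) and, by a much wider margin, of bromo on the same aromatic carbon (a 19-fold higher number from compound 2 to compound 4 (1.27 log units; beyond the scatter)). Among these four compounds, neither group on the chain carbon matches the unsubstituted methyl, and bromo gives the lowest number.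

The compounds shown do not separate the effect of losing the hydroxy from that of introducing the amine, a question that a methoxy or a primary amine on the same chain carbon would address. They also leave open whether the result with bromo is particular to that atom or would extend to chloro or a nitrile on the aromatic carbon.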